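Swapping the distal aryl on a biaryl sulfonamide in J774 cells

A few compounds are considered here, and "the series" means these few. Any claim that something is new, unique, unknown or untested is made for them only; others in the source may bear on it.

Compound 1 `O=S(=O)(Nc1cc(CO)ccc1O)c1ccc(-c2ccc(F)cc2F)cc1`: 200 nM
Compound 2 `O=S(=O)(Nc1ccc(CO)c(CO)c1)c1ccc(-c2ccc(F)cc2)cc1`: 1000 nM
Compound 3 `O=S(=O)(Nc1cccc(CO)c1)c1ccc(-c2ccc3[nH]ccc3c2)cc1`: > 5000 nM

Three biaryl sulfonamides have been tested in a functional assay on J774 cells (Mus musculus) for cytotoxicity, read by resazurin assay, with a stated time of 72 h; a lower number here means a stronger inhibitor, a higher number a weaker inhibitor. Compound 1 gives 200 nM. Compound 2 gives 1000 nM, a value that sits clearly higher than that of compound 1. Compound 3 returns only a limit, > 5000 nM, so its number is not known; this is the limit described in the limit of > 5000 nM in this assay, at which 1 of the 3 values shown sits, at which one of the three values stands. Going by the values given here, no two of the measured compounds differ in a single place, so no measured step is available to lean on.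

Compound 4 `CN(C)c1ccc(-c2ccc(S(=O)(=O)Nc3cccc(CO)c3)cc2)cc1` has not yet been measured in this assay. It differs from compound 3 by 4-(dimethylamino)phenyl in place of 1H-indol-5-yl on an aromatic carbon: the indole is replaced by 4-(dimethylamino)phenyl, with the hydrogen-bond donor exchanged for an acceptor, while the rest of the molecule, including the hydroxymethyl-bearing aniline and the sulfonamide, is unchanged.

Because compound 3 sits at the limit (the limit of > 5000 nM in this assay, at which 1 of the 3 values shown sits), no measured direction can be read from it. The step from compound 3 to compound 4 is expected to be a number no higher from compound 3 to compound 4 (the limit leaves the size open), which is to say no change beyond the scatter. Compound 4 is therefore estimated at 5000 nM, with a range from 1500 nM to 20000 nM, and a fair chance that the assay again reports only a limit.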

Compound 4, half-maximal inhibitory concentration: > 5000 nM
Compound 4: only a limit was reported (the forecaster's own chance of this, stated with the estimate: 50%); the middle value lies on the limit itself.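

In this assay compound 4 returns > 5000 nM as a limit. Compound 3 likewise returns > 5000 nM as a limit. No step can be read between compound 3 and compound 4, as both stand at the same limit: the limit of > 5000 nM in this assay, at which 2 of the 4 values shown sit. The compounds shown leave open whether 4-(dimethylamino)phenyl in place of 1H-indol-5-yl changes the value at all.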